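The source may hold more compounds than are shown below. What is called first, only, known or untested is meant among the compounds shown, and "the series" means these compounds.

Compound 3 `COc1cc(N(C)C)c(NC(=O)c2ccncc2)cc1Nc1nccc(-c2cn(C)c3ccccc23)n1` is the weakest of the three measured compounds in a functional assay on A549 cells (Homo sapiens) for antiproliferative activity, read by MTT assay, with a stated time of 72 h (on this read-out lower numbers stand for stronger inhibition and higher numbers for weaker inhibition), where compound 3 gives 9000 nM. Compound 1 `COc1cc(F)c(NC(=O)c2ccncc2OC)cc1Nc1nccc(-c2cn(C)c3ccccc23)n1` gives in this assay 3430 nM, and compound 2 `COc1cc(N(C)CCN(C)C)c(NC(=O)c2ccncc2OC)cc1Nc1nccc(-c2cn(C)c3ccccc23)n1` gives in this assay 2690 nM; both lie beyond the scatter away from compound 3, and both carry a methoxy group on their pyridine ring that compound 3 lacks. Compound 4 `COc1cc(N(C)C)c(NC(=O)c2ccncc2OC)cc1Nc1nccc(-c2cn(C)c3ccccc23)n1` restores that group: the change is methoxy in place of hydrogen on an aromatic carbon, placed two atoms from the ring nitrogen and ortho to a large group. Within the data shown here, no measured pair differs only in this way. Among the measured compounds shown here, the one single-place step on record, a 1.3-fold lower number from compound 1 to compound 2 (0.11 log units; within the scatter), concerns the substituent on the central aromatic ring and shows that swapping it leaves the number essentially unchanged; this suggests that the gap between compound 3 and compounds 1 and 2 is more plausibly tied to the methoxy on the pyridine than to the substituent on the central ring. Compound 4 is therefore expected to move toward the values of compounds 1 and 2, a step of a 2.8-fold lower number from compound 3 to compound 4 (0.45 log units; beyond the scatter) in this assay. The estimate for compound 4 in this assay is 3200 nM, with a range from 1500 nM to 7000 nM.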

Compound 4, half-maximal inhibitory concentration: 3030 nM
Compound 4: the middle estimate sits 1.1-fold (0.02 log units) above what was measured; the measured number falls inside the stated range.
By their numbers in this assay, from the lowest: compounds 2, 4 and 1 (each within the scatter of the next); then compound 3.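

Among these compounds, measured in this assay, methoxy in place of hydrogen on an aromatic carbon, two atoms from the ring nitrogen and ortho to a large group, gives a 3.0-fold lower number from compound 3 to compound 4 (0.47 log units; beyond the scatter), and this is the first pair to isolate the change at this position. With the methoxy present, the other site can now be read against the same background: dimethylamino in place of fluoro gives a 1.1-fold lower number from compound 1 to compound 4 (0.05 log units; within the scatter), and hydrogen in place of (dimethylamino)methyl gives a 1.1-fold higher number from compound 2 to compound 4 (0.05 log units; within the scatter), both within the scatter. Among the compounds shown here, of these three steps, only the one at the pyridine position lies beyond the scatter, although it is modest and all four compounds remain in the same low micromolar region of the printed values.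

From the compounds shown here alone, whether the step is specific to methoxy, or would also appear with ethoxy, fluoro or an amine on this carbon, stays open, as does whether adding methoxy would give the same step in compounds carrying fluoro or the longer amine chain. Nothing in hand accounts for why this change alters the number.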